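This account rests on a few compounds, and the source may have more. Where it says the series, first, only, none or still open, it means among the compounds named here.

Three compounds have been measured in a functional assay on HeLa cells for antagonist activity at 5-hydroxytryptamine receptor 6 (Homo sapiens); on this read-out higher numbers stand for weaker inhibition and lower numbers for stronger inhibition:

- compound 1 `Cc1ccc(S(=O)(=O)c2n[nH]c3ccc(N4CCN(C)CC4)cc23)cc1` gives 112 nM
- compound 2 `COc1cccc(S(=O)(=O)c2n[nH]c3ccc(N4CCN(C)CC4)cc23)c1` gives 57 nM
- compound 3 `COc1ccc(S(=O)(=O)c2n[nH]c3ccc(N4CCN(C)CC4)cc23)cc1` gives 544 nM

On these numbers compound 3 stands highest of the three. Its nearest neighbour is compound 1, a step described as a 4.9-fold higher number from compound 1 to compound 3 (0.69 log units; beyond the scatter); its furthest is compound 2, with a 9.5-fold higher number from compound 2 to compound 3 (0.98 log units; beyond the scatter). The remaining step, a 2.0-fold lower number from compound 1 to compound 2 (0.29 log units; within the scatter), is within the scatter.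

Compound 4 `CN1CCN(c2ccc3[nH]nc(S(=O)(=O)c4ccc(Cl)cc4)c3c2)CC1` is not yet measured. It differs from compound 3 in one place: chloro in place of methoxy on an aromatic carbon. The group that leaves is the one that enters in the step from compound 1 to compound 3, where the methyl of compound 1 was replaced by methoxy on the same aromatic carbon, and a 4.9-fold higher number from compound 1 to compound 3 (0.69 log units; beyond the scatter) was the result. That step is the one that bears most directly on the present change, since it shows that swapping the group at this position, para to a large group, moves the number beyond the scatter. Chloro is neither of the two groups already seen there, so the direction is inferred rather than shown; the single comparison suggests that leaving methoxy is more likely to lower than to raise the number.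

Compound 4 is therefore expected to give 150 nM, in a range from 50 nM to 450 nM, which is an estimated step of a 3.6-fold lower number from compound 3 to compound 4 (0.56 log units; beyond the scatter).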

Compound 4, half-maximal inhibitory concentration: 108 nM
Compound 4: the middle estimate sits 1.4-fold (0.14 log units) above what was measured; the range from low to high includes it.
By their numbers in this assay, from the lowest: compounds 2, 4 and 1 (each within the scatter of the next); then compound 3.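

In this assay, replacing methoxy with chloro on this aromatic carbon, para to a large group, gives a 5.0-fold lower number from compound 3 to compound 4 (0.70 log units; beyond the scatter) and so shows that methoxy can be left behind with a second group, not only with the methyl of compound 1. Chloro and methyl cannot be told apart at this place (a 1.0-fold lower number from compound 1 to compound 4 (0.02 log units; within the scatter)), so of the three groups seen on this carbon, only methoxy stands apart from the others. The 4-chlorophenyl of compound 4 and the 3-methoxyphenyl of compound 2 also lie within the scatter of each other (a 1.9-fold higher number from compound 2 to compound 4 (0.28 log units; within the scatter)), which leaves the 4-methoxyphenyl of compound 3 as the only aryl group shown here whose steps to all the others are beyond the scatter.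

Going by these compounds, it remains open whether an amine, a carboxylic acid or a longer chain such as ethoxy on this carbon would read with chloro and methyl or with methoxy. The compounds shown come with no measurement that accounts for the difference between methoxy and the other two groups at this place.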